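This account rests on a few compounds, and the source may have more. Where it says the series, first, only, none or still open, it means among the compounds named here.

Of the compounds shown here, three sharing one core have been measured in a functional assay on MGC-803 cells (Homo sapiens) for inhibition, read by MTT assay, with a stated time of 48 h; a lower number here means a stronger inhibitor, a higher number a weaker inhibitor. Compound 1 `CCC(=O)N(Cc1ccc(OC)c(O)c1)c1cc(OC)c(OC)c(OC)c1` gives 50 nM. Compound 2 `COc1ccc(CN(C(=O)CCCl)c2cc(OC)c(OC)c(OC)c2)cc1O` gives 140 nM, and compound 3 `COc1ccc(CN(C(=O)CBr)c2cc(OC)c(OC)c(OC)c2)cc1O` gives 140 nM; compound 3 thus stands level with compound 2, the two together the highest numbers of the three, and the gap from the lowest number is a 2.8-fold higher number from compound 1 to compound 3 (0.45 log units; beyond the scatter). Compound 4 `COc1ccc(CN(C(=O)/C=C/CBr)c2cc(OC)c(OC)c(OC)c2)cc1O` differs from compound 3 by 3-bromoprop-1-en-1-yl in place of bromomethyl on a carbonyl carbon. The steps that alter the group on the carbonyl carbon are a 2.8-fold higher number from compound 1 to compound 2 (0.45 log units; beyond the scatter), a 2.8-fold higher number from compound 1 to compound 3 (0.45 log units; beyond the scatter) and no change at the digits printed from compound 2 to compound 3 (within the scatter); the last, exchanging one bromine- or chlorine-bearing chain for another, stayed within the scatter. Compound 4 again carries a bromine-bearing chain on that carbon, so the step is expected to be small, no change at the digits printed from compound 3 to compound 4 (within the scatter), and compound 4 is estimated at 140 nM, within a range from 50 nM to 400 nM.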

Compound 4, half-maximal inhibitory concentration: 71 nM
For compound 4 the middle estimate is 2.0-fold (0.29 log units) above the measured one; the measured number falls inside the stated range.
By their numbers in this assay, from the lowest: compounds 1, 4, 2 and 3 (each within the scatter of the next, the first and the last beyond it).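

Placed on the carbonyl carbon, 3-bromoprop-1-en-1-yl, with its double bond, is accommodated in this assay: replacing bromomethyl gives a 2.0-fold lower number from compound 3 to compound 4 (0.29 log units; within the scatter), and replacing 2-chloroethyl gives a 2.0-fold lower number from compound 2 to compound 4 (0.29 log units; within the scatter). Set against plain ethyl, it gives a 1.4-fold higher number from compound 1 to compound 4 (0.15 log units; within the scatter), so compound 4 cannot be separated from compound 1, compound 2 or compound 3, although compound 2 and compound 3 are separated from compound 1. Nothing available accounts for these numbers. As far as these compounds go, whether the double bond or the bromine matters more stays open, as does how an amine or a carboxylic acid in place of the bromine would read in this assay.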